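The compounds below may be only part of what the source reports. "The series", "measured", "known", "first", "only" and "open" are said of these compounds alone.

Measured compounds:
compound 1, `COc1cccc(-c2cnc(NC(=O)c3ccc(F)cc3)n2C)c1`, > 100000 nM
compound 2, `COc1ccc(-c2cnc(NC(=O)C3CCCC3)n2C)cc1`, > 100000 nM
compound 3, `COc1cccc(-c2cnc(NC(=O)c3ncc[nH]3)n2C)c1`, > 100000 nM

In a toxicity assay on THP-1 cells (Homo sapiens) for inhibition (on this read-out lower numbers stand for higher toxicity in this test and higher numbers for lower toxicity in this test), compound 1 gives > 100000 nM, which is a limit of the assay rather than a number. Compound 2 likewise gives > 100000 nM in this assay, again a limit. Compound 3 gives > 100000 nM in this assay, also a limit. Among the measured compounds shown here, the one step between measured compounds that differ in a single place, a step that the two limits leave unreadable from compound 1 to compound 3, therefore cannot be read in size or direction. Compound 1 thus stands at the limit, as do the two other measured compounds, because of the limit of > 100000 nM in this assay, at which 3 of the 3 values shown sit.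

Compound 4, `Cn1c(-c2cccc(Cl)c2)cnc1NC(=O)c1ccc(F)cc1`, differs from compound 1 by chloro in place of methoxy on an aromatic carbon. For the measured compounds named here, no measured step bears on this change, and the only measured step is unreadable. Given that all three measured values sit at the limit, compound 4 is expected to sit there as well, with a step of a number no higher from compound 1 to compound 4 (the limit leaves the size open) that means no change beyond the scatter. The estimate for compound 4 in this assay is 100000 nM, within 40000 nM to 250000 nM.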

Compound 4, half-maximal cytotoxic concentration: > 50000 nM
Compound 4 was reported as a limit (the forecaster's own chance of this, stated with the estimate: 75%); the middle value is on the limit's open side.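

In this assay compound 4 gives > 50000 nM, which is a limit of the assay and not a number. Compound 1 also sits at a limit, so the step to compound 4 cannot be read. The compounds shown leave open what structural change, if any, would bring a measurable value in this assay.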